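The compounds below may be only part of what the source reports. "The series", "measured", "known", "first", "only" and "open" are said of these compounds alone.

In a functional assay on HeLa cells (Homo sapiens) for cytotoxicity, read by MTT assay, with a stated time of 72 h, tested at 30 uM (on this read-out higher numbers stand for more inhibition of growth at the one concentration tested and lower numbers for less inhibition of growth), compound 1 `Cc1ccnc(/C(N)=N/NC(=S)N2CCSCC2)c1` gives 78.3%. Its number is the lowest of the three measured, yet neither other compound is separated from it beyond the scatter: compound 2 `N/C(=N\NC(=S)N1CCSCC1)c1ccccn1` gives 80.6%, and compound 3 `Cc1cccc(/C(N)=N/NC(=S)N2CCCCCC2)n1` gives 81.2%. Among the measured compounds shown here, the one single-point step among the measured compounds, hydrogen in place of methyl on an aromatic carbon, is a number 2.3 percentage points higher from compound 1 to compound 2 (within the scatter). Compound 3 carries a different ring on the thiocarbonyl carbon together with a shifted methyl, so its value and that of compound 1 show only that the two lie close.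

Compound 4 `Cc1ccnc(/C(N)=N/NC(=S)N2CCCC2)c1` differs from compound 1 by pyrrolidin-1-yl in place of thiomorpholin-4-yl on a thiocarbonyl carbon. For the measured compounds named here, no measured step changes the ring on the thiocarbonyl carbon alone, so the only guide is that all three measured numbers sit together within the scatter. The step expected from this change is therefore none beyond the scatter, a number 1.3 percentage points lower from compound 1 to compound 4 (within the scatter). Compound 4 is thus estimated at 77%, within a range from 60% to 90%.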

Compound 4, percent growth inhibition at one concentration: 86.4%
Beside the measured number, compound 4's estimate is 9.4 percentage points below it; measured number inside the range.
By their numbers in this assay, from the lowest: compounds 1, 2, 3 and 4 (each within the scatter of the next).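

In this assay, among the compounds shown here, the exchange of thiomorpholin-4-yl for pyrrolidin-1-yl on a thiocarbonyl carbon gives the first single-place reading at this position: a number 8.1 percentage points higher from compound 1 to compound 4 (within the scatter). On the core of compound 1, then, the ring at this position can go from six-membered to five-membered and lose its sulfur without a step beyond the scatter. Nothing available here explains this result.

Still open, going by these compounds, is whether a morpholin-4-yl or piperazin-1-yl ring, or an open-chain dimethylamino group, in the same place would also stay within the scatter of compound 1. On these data alone, it is also open whether pyrrolidin-1-yl would give a similar reading on the core of compound 2, which lacks the methyl group.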